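From iodo to methoxy: working notes on the series

The source may report more compounds than this note shows. Statements on the series, on what has been measured and on what is new or still open speak of the compounds shown alone.

- compound 1 `NC(=O)c1cc(Cl)ccc1NC(=O)COc1ccccc1` gives 5420 nM
- compound 2 `NC(=O)c1cc(I)ccc1NC(=O)COc1ccccc1` gives 701 nM
- compound 3 `COc1ccc(NC(=O)COc2ccccc2)c(C(N)=O)c1` is not yet measured

Going by the values given here, in a functional assay on UACC-62 cells (Homo sapiens) for inhibition (a higher number here means a weaker inhibitor of growth, a lower number a stronger inhibitor of growth), compound 2 (701 nM) has the lower of the two numbers so far. Compound 3 carries methoxy in place of iodo on an aromatic carbon. Among the compounds with values here, one measured step bears on this change: a 7.7-fold lower number from compound 1 to compound 2 (0.89 log units; beyond the scatter) (iodo in place of chloro), a modest step beyond the scatter. Within the data shown here, no measured compound carries methoxy, so any reading for it is indirect. Among the measured compounds shown here, with compound 1 (5420 nM) as the only guide, losing iodo is expected to cost a step of similar size, towards a higher number. The expected step is a 5.7-fold higher number from compound 2 to compound 3 (0.76 log units; beyond the scatter) with wide uncertainty. The estimate for compound 3 is 4000 nM (expected range 1200 nM to 15000 nM).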

Compound 3, concentration for 50% growth inhibition: 1050 nM
The estimate for compound 3 lay 3.8-fold (0.58 log units) above the measured number, outside the stated range (below it).
By their numbers in this assay, from the lowest: compounds 2 and 3 (each within the scatter of the next); then compound 1.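

In this assay, the gain over chloro at this position, para to a large group, is not tied to iodo: a 1.5-fold higher number from compound 2 to compound 3 (0.18 log units; within the scatter), so methoxy and iodo cannot be told apart here. Chloro is the group that stands apart among the three, with a 5.2-fold lower number from compound 1 to compound 3 (0.71 log units; beyond the scatter), which shows that two quite different groups, one a single iodine atom and the other carrying a hydrogen-bond acceptor, give readings within the scatter of each other. Nothing on hand accounts for why chloro differs from the other two.

Going by these compounds, whether an amine, a bromo group or a longer chain such as ethoxy at this position would stay level with compound 2 and compound 3 or fall back towards compound 1 remains open. On these data alone, all three compounds share one core, so it is also open whether this reading would hold with a carboxylic acid in place of the carbamoyl group.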